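The compounds below may be only part of what the source reports. "The series", "measured", "known", "first", "only" and "open" are said of these compounds alone.

Among the measured compounds shown here, in a functional assay on B16-F10 cells (Mus musculus) for antiproliferative activity, read by MTT assay, with a stated time of 48 h (a higher number here means a weaker inhibitor, a lower number a stronger inhibitor), compound 1 `CC(=O)N1N=C(c2ccc3ccccc3c2)OC1c1cccc(Br)c1` gives 2.36 ug/mL, the lowest number among the three compounds measured so far. Compound 2 `CC(=O)N1N=C(c2ccc3ccccc3c2)OC1c1ccc(Br)cc1` gives 4.68 ug/mL, and compound 3 `CC(=O)N1N=C(c2ccc3ccccc3c2)OC1c1ccccc1Cl` gives 4.93 ug/mL. Compound 4 `CC(=O)N1N=C(c2ccc3ccccc3c2)OC1c1ccncc1` differs from compound 1 by pyridin-4-yl in place of 3-bromophenyl on a saturated ring carbon. The measured steps that bear on this each swap one group on the same saturated ring carbon: a 2.0-fold higher number from compound 1 to compound 2 (0.30 log units; within the scatter), a 2.1-fold higher number from compound 1 to compound 3 (0.32 log units; beyond the scatter) and a 1.1-fold higher number from compound 2 to compound 3 (0.02 log units; within the scatter). Every one of these swaps gave a step of small size, yet none brought in a pyridin-4-yl, so the guidance is weak. The expected step is a 2.1-fold higher number from compound 1 to compound 4 (0.33 log units; beyond the scatter), a modest rise in keeping with those. For compound 4 the estimate in this assay is 5 ug/mL, with a range from 2 ug/mL to 12 ug/mL.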

Compound 4, half-maximal inhibitory concentration: 2.97 ug/mL
Beside the measured number, compound 4's estimate is 1.7-fold (0.23 log units) above it; measured number inside the range.
By their numbers in this assay, from the lowest: compounds 1, 4, 2 and 3 (each within the scatter of the next, the first and the last beyond it).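

In this assay the swap to pyridin-4-yl gives a 1.3-fold higher number from compound 1 to compound 4 (0.10 log units; within the scatter) and a 1.6-fold lower number from compound 2 to compound 4 (0.20 log units; within the scatter) and a 1.7-fold lower number from compound 3 to compound 4 (0.22 log units; within the scatter) and all three lie within the scatter. Until now this saturated ring carbon had carried only halogen-bearing phenyl rings, and these steps show that a ring with a nitrogen and no halogen, bringing a hydrogen-bond acceptor, gives a number not distinguishable from theirs. No measurement here explains why this change is accepted.

The compounds shown leave open whether an aromatic ring is needed on this carbon at all, and how an amine, a carboxylic acid or a longer alkyl chain there would behave.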